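A few compounds are considered here, and "the series" means these few. Any claim that something is new, unique, unknown or untested is made for them only; others in the source may bear on it.

Three compounds sharing one core have been examined in a functional assay on MDA-MB-231 cells (Homo sapiens) for cytotoxicity, read by MTT assay, with a stated time of 48 h; a lower number here means a stronger inhibitor, a higher number a weaker inhibitor. Compound 1, `CCn1c(/C=C2/C(=O)Nc3ccc(Br)cc32)nc2ccccc21`, carries an ethyl group on the core, and for it the result is "not determined" (no result reported). Compound 3, `CC(C)n1c(/C=C2/C(=O)Nc3ccc(Cl)cc32)nc2ccccc21`, carries an isopropyl group and a chloro substituent and gives 25100 nM, a weak result. Compound 2, `Cn1c(/C=C2/C(=O)Nc3ccc(Br)cc32)nc2ccccc21`, carries a methyl group and a bromo substituent. In this assay compound 2 reaches only a limit of the assay, > 50000 nM, so no single number stands for it; among the results shown it sits at the weak end, with no measured step connecting it to any other compound.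

Compound 4, `Cn1c(/C=C2/C(=O)Nc3ccc(F)cc32)nc2ccccc21`, differs from compound 2 in a single place: fluoro in place of bromo on an aromatic carbon. For the measured compounds named here, no measured pair of compounds shows what this exchange does here, so the size of the step cannot be read from the data; only the surroundings can be taken into account.

Because compound 2 sits at the limit of > 50000 nM in this assay, at which 1 of the 3 values shown sits, the neighbourhood of this change is one of very weak inhibition, and a shift beyond the usual scatter is not expected in either direction. Compound 4 is therefore expected to remain a weak inhibitor, with an estimated value of 60000 nM and a range from 15000 nM to 250000 nM. The estimated step is a step that the limit leaves unreadable from compound 2 to compound 4.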

Compound 4, half-maximal inhibitory concentration: 21700 nM
The estimate for compound 4 lay 2.8-fold (0.44 log units) above the measured number, and the stated range covers the measured number.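

This pair gives the first measured view of a single change on this aromatic carbon, meta to a fused ring and para to a fused ring: in this assay, fluoro in place of bromo gives an at least 2.3-fold lower number from compound 2 to compound 4 (0.36 log units; beyond the scatter), with the methyl group and the rest of the molecule unchanged. The group at this place can therefore shift the read-out on its own, although compound 4, at 21700 nM, is still a weak inhibitor. Only a lower bound can be given for the size of this step, because the starting point for compound 2 is a limit of the assay and not a number: the limit of > 50000 nM in this assay, at which 1 of the 4 values shown sits.

The pair shows that the result changes with this exchange but not why, and it leaves open whether a plain hydrogen, a methoxy group, an amine or a carboxylic acid on the same carbon would give a stronger or a weaker inhibitor. It also leaves open how a longer chain, such as butyl, in place of the methyl group would act alongside the fluoro of compound 4.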